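The compounds below may be only part of what the source reports. "The series", "measured", "known", "first", "only" and "open" are said of these compounds alone.

In an ADME assay on L6 cells (Rattus norvegicus) for cytotoxicity, read by resazurin assay, with a stated time of 72 h (on this read-out lower numbers stand for stronger inhibition and higher numbers for weaker inhibition), compound 1 `CCN(CC)CC(=O)OC1CC2(N(C)C)CC(c3ccccc3)C1C(c1ccccc1)C2` gives 30100 nM as its half-maximal inhibitory concentration. Compound 2 `CN1CCN(CCC(=O)NC2CC3(N(C)C)CC(c4ccccc4)C2C(c2ccccc2)C3)CC1` gives 95000 nM in the same test, the higher of the two numbers, and the gap between them lies beyond the scatter of repeat measurements. Compound 2 therefore stands as the weaker inhibitor of this pair. Compound 3 `CN1CCN(CC(=O)NC2CC3(N(C)C)CC(c4ccccc4)C2C(c2ccccc2)C3)CC1` has not yet been measured. It differs from compound 2 in one place, on a saturated chain carbon bound to a carbonyl carbon, where 4-methylpiperazin-1-yl stands in place of (4-methylpiperazin-1-yl)methyl, and the change is counted as 4-methylpiperazin-1-yl in place of (4-methylpiperazin-1-yl)methyl on a saturated chain carbon bound to a carbonyl carbon in full. Going by the values given here, no measured pair shows what this change does, so any forecast rests on little. Only a small effect is expected, with no step beyond the scatter in this assay and a slight lean toward a lower number. The expected move is a 1.4-fold lower number from compound 2 to compound 3 (0.13 log units; within the scatter) on this estimate. For compound 3 an estimated 70000 nM is expected in this assay with a range from 30000 nM to 140000 nM for repeat measurements.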

Compound 3, half-maximal inhibitory concentration: 66200 nM
For compound 3 the middle estimate is 1.1-fold (0.02 log units) above the measured one, and the stated range covers the measured number.
By their numbers in this assay, from the lowest: compound 1; then compounds 3 and 2 (each within the scatter of the next).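

In this assay, going by these compounds alone, the step of a 1.4-fold lower number from compound 2 to compound 3 (0.16 log units; within the scatter) gives the first reading of 4-methylpiperazin-1-yl in place of (4-methylpiperazin-1-yl)methyl on a saturated chain carbon bound to a carbonyl carbon, and it shows that this assay does not separate the two groups at this place. The step of a 2.2-fold higher number from compound 1 to compound 3 (0.34 log units; beyond the scatter) is a modest one, with (((4-methylpiperazin-1-yl)methyl)carbonyl)amino in place of (((diethylamino)methyl)carbonyl)oxy on a saturated ring carbon, so the group at that ring carbon does register here even though the chain change does not. Nothing available explains either step.

That second exchange alters the amine and the link to the ring carbon together, so the compounds shown leave open which of the two carries the step. They also leave open whether a longer chain such as 3-(4-methylpiperazin-1-yl)propyl, or a morpholin-4-yl group in place of 4-methylpiperazin-1-yl, would stay within the scatter of compound 3 in this assay or move beyond it.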